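The source may hold more compounds than are shown below. What is called first, only, known or untested is meant among the compounds shown, and "the series" means these compounds.

Measured so far in a physicochemical assay for solubility, in phosphate buffer, at pH 6.5; a lower number here means a less soluble compound, a higher number a more soluble compound:
- Compound 1 `C=C[C@@H]1C[C@]1(NC(=O)[C@@H]1C[C@@H](Oc2nccc3cc(OC)ccc23)CN1C(=O)[C@@H](NC(=O)N[C@H](C(=O)OC)C(C)(C)C)C(C)(C)C)C(=O)NS(=O)(=O)C1CC1`: 754 ug/mL
- Compound 2 `C=C[C@@H]1C[C@]1(NC(=O)[C@@H]1C[C@@H](Oc2nccc3cc(OC)ccc23)CN1C(=O)[C@@H](NC(=O)N[C@H](C(=O)NCc1ccccc1)C(C)(C)C)C(C)(C)C)C(=O)NS(=O)(=O)C1CC1`: 95 ug/mL

Of these two compounds, compound 2 has the lower number in this assay, at 95 ug/mL. Compound 3 `C=C[C@@H]1C[C@]1(NC(=O)[C@@H]1C[C@@H](Oc2nccc3cc(OC)ccc23)CN1C(=O)[C@@H](NC(=O)N[C@H](C(=O)N1CCN(c2ncccn2)CC1)C(C)(C)C)C(C)(C)C)C(=O)NS(=O)(=O)C1CC1` has not been measured. It differs from compound 2 in one place, with 4-(pyrimidin-2-yl)piperazin-1-yl in place of benzylamino on a carbonyl carbon.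

Among the measured compounds shown here, only one measured step bears on this change, as it sits at the same carbonyl carbon: a 7.9-fold lower number from compound 1 to compound 2 (0.90 log units; beyond the scatter). That single step shows that a swap here can matter, but neither measured compound carries the entering group, so it fixes no direction. No step beyond the scatter is therefore expected in this assay, though with real uncertainty. The expected change is a 1.3-fold higher number from compound 2 to compound 3 (0.10 log units; within the scatter). Compound 3 is estimated at 120 ug/mL, with an expected range of 35 ug/mL to 400 ug/mL.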

Compound 3, solubility: 132 ug/mL
Compound 3: the middle estimate sits 1.1-fold (0.04 log units) below what was measured; measured number inside the range.
By their numbers in this assay, from the lowest: compounds 2 and 3 (each within the scatter of the next); then compound 1.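

In this assay, putting 4-(pyrimidin-2-yl)piperazin-1-yl in place of benzylamino on this carbonyl carbon gives a 1.4-fold higher number from compound 2 to compound 3 (0.14 log units; within the scatter) and so no real separation, even though the two groups differ in their rings, their nitrogen count and their hydrogen-bond donors and acceptors. Against methoxy, the same group gives a 5.7-fold lower number from compound 1 to compound 3 (0.76 log units; beyond the scatter) and so, like benzylamino, stands clearly apart from the methoxy compound. Nothing measured here explains either result. Still open, as far as these compounds go, is whether a ring on this carbonyl carbon is needed for the lower number, or whether any amine would do. A ring-free group such as dimethylamino, or a morpholine ring with its oxygen atom, would help to tell these apart.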